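Non-Aromatic Ring Replaces Trifluoromethoxyphenyl on the Shared Core

The compounds below may be only part of what the source reports. "The series", "measured", "known", "first", "only" and "open" are said of these compounds alone.

Compound 1 `C[C@H](Oc1cccc(Cl)c1Cl)C(=O)Nc1ccc2oc(-c3ccc(OC(F)(F)F)cc3)nc2c1` gives in an assay on isolated protein for inhibition of GMP reductase 2 (Homo sapiens), read by spectrophotometry (on this read-out lower numbers stand for stronger inhibition and higher numbers for weaker inhibition), only a limit of the assay, > 5000 nM, not a number.
Compound 2 `C[C@H](Oc1cccc(F)c1F)C(=O)Nc1ccc2oc(-c3ccc(O)cc3)nc2c1` gives in this assay only a limit, > 5000 nM, not a number.
Compound 3 `C[C@H](Oc1cccc(F)c1F)C(=O)Nc1ccc2oc(-c3ccncc3)nc2c1` gives in this assay only a limit, > 5000 nM, not a number.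

Compound 1 therefore stands where every measured compound stands: at the limit of > 5000 nM in this assay, at which 3 of the 3 values shown sit. Going by the values given here, no compound in this set has a measured inhibition constant, so there is no ordering among them.

Compound 4 `C[C@H](Oc1cccc(Cl)c1Cl)C(=O)Nc1ccc2oc(C3=CC=NCC3=O)nc2c1` differs from compound 1 by a group of 7 heavy atoms (5 carbon, 1 nitrogen, 1 oxygen; one six-membered non-aromatic ring with 1 hetero atom) in place of a group of 11 heavy atoms (7 carbon, 1 oxygen, 3 fluorine; one six-membered aromatic ring of carbon only), on an aromatic carbon. Among the compounds with values here, the only step measured between compounds that differ in one place, a step that the two limits leave unreadable from compound 2 to compound 3, changes the group at the same kind of position, but it runs between two limits and its size cannot be read. Within the data shown here, it does not involve the groups that leave or enter here, so no measured step tells how large the change from compound 1 to compound 4 should be, or in which direction.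

With three limits and no readable step, the expectation for compound 4 is that it most likely also sits at the limit of this assay; its inhibition constant is estimated at 5000 nM, with a range from 1500 nM to 20000 nM. The step this estimate means, a number no higher from compound 1 to compound 4 (the limit leaves the size open), is expected to be none beyond the scatter.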

Compound 4, inhibition constant: > 5000 nM
Compound 4 ended at the assay's limit; the forecaster's own chance of this, stated with the estimate: 80%; the middle value lies on the limit itself.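

Compound 1 and compound 4 each give only a limit in this assay, not a number, so no step between them can be read: the limit of > 5000 nM in this assay, at which 4 of the 4 values shown sit.

Left open is how strongly any of these compounds inhibits the protein, and whether changing the group on the shared core alters that inhibition at all.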